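A few compounds are considered here, and "the series" means these few. Any claim that something is new, unique, unknown or untested is made for them only; others in the source may bear on it.

Measured compounds:
compound 1 `O=S(=O)(NCCCNc1nccc(-c2c(-c3cccc(F)c3)nc3sccn23)n1)c1cccc(F)c1` — in a functional assay on SK-MEL-28 cells (Homo sapiens) for cytotoxicity, read by MTT assay (on this read-out lower numbers stand for stronger inhibition and higher numbers for weaker inhibition), compound 1 gives 8550 nM
compound 2 `O=S(=O)(NCCNc1nccc(-c2c(-c3cccc(F)c3)nc3sccn23)n1)c1ccccc1` — in this assay compound 2 gives 19000 nM

Compound 2 stands highest of the two numbers; its nearest is compound 1, one step away: a 2.2-fold higher number from compound 1 to compound 2 (0.35 log units; beyond the scatter). Compound 3 `O=C(NCCCNc1nccc(-c2c(-c3cccc(F)c3)nc3sccn23)n1)c1ccc(F)cc1` differs from compound 2 by (((4-fluorophenyl)carbonyl)amino)methyl in place of (phenylsulfonyl)amino on a saturated chain carbon, two bonds along the chain from a nitrogen on an aromatic ring. Among the measured compounds shown here, the only step that bears on it is the one from compound 1 to compound 2, which lengthens the chain in the opposite direction and is modest; the change from a sulfonyl to a carbonyl linkage has no measured counterpart here. A modest lower number is therefore expected for compound 3, about a 2.1-fold lower number from compound 2 to compound 3 (0.32 log units; beyond the scatter), with wide uncertainty. Compound 3 is estimated at 9000 nM in this assay, within 3000 nM to 30000 nM.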

Compound 3, half-maximal inhibitory concentration: > 20000 nM
Compound 3 was reported as a limit; the forecaster's own chance of this, stated with the estimate: 10%; middle value at least 2.2-fold (0.34 log units) from the limit.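

In this assay, among the compounds shown here, (4-fluorophenyl)carbonyl in place of (3-fluorophenyl)sulfonyl on an amine nitrogen gives an at least 2.3-fold higher number from compound 1 to compound 3 (0.36 log units; beyond the scatter), the first measured change of the sulfonyl linkage. Against the other sulfonyl compound the reading is only an at least 1.0-fold higher number from compound 2 to compound 3 (0.02 log units; that floor lies within the scatter), so no order between those two can be stated. Compound 3 is reported only as a limit: the limit of > 20000 nM in this assay, at which 1 of the 3 values shown sits.

From the compounds shown here alone, the step from compound 1 changes the linkage and the fluorophenyl group together, so their shares stay open. Also open, going by these compounds, is how (3-fluorophenyl)carbonyl or (4-fluorophenyl)sulfonyl on that nitrogen, or a longer chain, would read.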